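The source may hold more compounds than are shown below. What is called first, only, known or untested is meant among the compounds shown, and "the series" means these compounds.

The measured compounds in an ADME assay on MDBK cells (Bos taurus) for cytotoxicity, read by MTT assay, with a stated time of 96 h (on this read-out lower numbers stand for higher toxicity in this test and higher numbers for lower toxicity in this test), are these. Compound 1 `O=[N+]([O-])c1ccc(-c2nc3cc(C(F)(F)F)ccc3[nH]2)cc1` gives 6000 nM. Compound 2 `O=[N+]([O-])c1ccc(-c2nc3cc(C(F)(F)F)ccc3[nH]2)c([N+](=O)[O-])c1` gives 16000 nM. Compound 3 `COc1ccc(-c2nc3cc(C(F)(F)F)ccc3[nH]2)cc1` gives > 100000 nM, which is a limit of the assay and not a number.

Compound 2 differs from compound 1 by nitro in place of hydrogen on an aromatic carbon, and this made a 2.7-fold higher number from compound 1 to compound 2 (0.43 log units; beyond the scatter). The core of compound 3 differs from that of compound 1 by methoxy in place of nitro on an aromatic carbon, with an at least 16-fold higher number from compound 1 to compound 3 (1.22 log units; beyond the scatter).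

Compound 4 `COc1ccc(-c2nc3cc(C(F)(F)F)ccc3[nH]2)c([N+](=O)[O-])c1` has not yet been measured. It differs from compound 3 by nitro in place of hydrogen on an aromatic carbon, the same kind of change as from compound 1 to compound 2; the surroundings are not identical, since the entering group is meta to a methoxy group (2 heavy atoms) rather than meta to a nitro group (3 heavy atoms).

Compound 3 already sits at the limit of > 100000 nM in this assay, at which 1 of the 3 values shown sits, so compound 4 is expected to show a limit too, with an expected step that the limit leaves unreadable from compound 3 to compound 4. The value estimated for compound 4 is 150000 nM, expected between 60000 nM and 400000 nM.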

Compound 4, half-maximal cytotoxic concentration: 55000 nM
Beside the measured number, compound 4's estimate is 2.7-fold (0.44 log units) above it, outside the stated range (below it).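

In this assay, nitro in place of hydrogen gives an at least 1.8-fold lower number from compound 3 to compound 4 (0.25 log units; that floor lies within the scatter), so on this core the change does not repeat the rise seen on the core of compound 1: the same change on two cores in this assay, a 2.7-fold higher number (0.43 log units; beyond the scatter) from compound 1 to compound 2 and an at least 1.8-fold lower number (0.25 log units; that floor lies within the scatter) from compound 3 to compound 4, at least 4.8-fold (0.68 log units) apart, beyond the scatter of two such steps

Methoxy in place of nitro raises the number on both cores, with a 3.4-fold higher number from compound 2 to compound 4 (0.54 log units; beyond the scatter), but the size of that rise does not carry over: the same change on two cores in this assay, an at least 16-fold higher number (1.22 log units; beyond the scatter) from compound 1 to compound 3 and a 3.4-fold higher number (0.54 log units; beyond the scatter) from compound 2 to compound 4, at least 4.8-fold (0.68 log units) apart, beyond the scatter of two such steps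

As far as these compounds go, compound 3 gives > 100000 nM, which is a limit of the assay and not a number, so the true size of the step from it stays unknown, and two cores are too few to give a rule for any other core.

The compounds shown leave open how an amine or a carboxylic acid in the place of the methoxy or nitro group would behave in this test. They also do not explain why the same change gives different results on the two cores.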